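This account rests on a few compounds, and the source may have more. Where it says the series, first, only, none or still open, it means among the compounds named here.

Measured in a functional assay on Jurkat cells (Homo sapiens) for inhibition; on this read-out lower numbers stand for stronger inhibition and higher numbers for weaker inhibition:
compound 1 `CCOC(=O)c1cnc(N(C(=O)OCC)N2C(=O)C=C(C)C2=O)nc1C(F)(F)F`: 380 nM
compound 2 `CCOC(=O)c1cnc(NN2C(=O)C=C(C)C2=O)nc1Cc1ccccc1`: 3800 nM

Compound 2 has the highest of these two numbers in this assay; compound 1 gives a lower number, and that gap lies beyond the usual scatter. Compound 3 `CCOC(=O)c1cnc(NN2C(=O)C=C(C)C2=O)nc1-c1cc2ccccc2s1` differs from compound 2 in one place: 1-benzothiophen-2-yl in place of benzyl on an aromatic carbon. For the measured compounds named here, no measured pair shows what this change does, so the direction of the step in this assay is open; a moderate step either way, or none beyond the scatter, is plausible. Compound 3 is expected to give about 2500 nM, between 600 nM and 12000 nM, which means an expected step of a 1.5-fold lower number from compound 2 to compound 3 (0.18 log units; within the scatter).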

Compound 3, half-maximal inhibitory concentration: 800 nM
Beside the measured number, compound 3's estimate is 3.1-fold (0.49 log units) above it, and the stated range covers the measured number.
By their numbers in this assay, from the lowest: compound 1; then compound 3; then compound 2.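

In this assay the group on this aromatic carbon clearly affects the result: 1-benzothiophen-2-yl in place of benzyl gives a 4.8-fold lower number from compound 2 to compound 3 (0.68 log units; beyond the scatter) and this step lies beyond the scatter. The change replaces both the benzyl carbon link and the ring system, so this single pair cannot separate the two. Nothing available explains the step. Still open, as far as these compounds go, is whether a plain phenyl or a thiophene ring on this carbon would give a similar number. An amine or a carboxylic acid here also remains untested in the compounds shown.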